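The source may hold more compounds than are shown below. What is called first, only, known or untested is meant among the compounds shown, and "the series" means these compounds.

Measured compounds:
compound 1, `CC(C)(c1cc([C@]23CCOC[C@H]2C3)nc(-c2ccc(NC(=S)NCCO)cc2)n1)S(C)(=O)=O`, 1.4 mL.min-1.g-1 in an ADME assay on microsomes (Rattus norvegicus) for metabolic stability; a higher number here means faster removal of the compound, a lower number slower removal
compound 2, `CCNC(=O)Nc1ccc(-c2nccc([C@@]34CCOC[C@@H]3C4)n2)cc1`, 16.7 mL.min-1.g-1

Of the compounds shown here, two have been measured in this assay. Compound 1 gives 1.4 mL.min-1.g-1. Compound 2 gives 16.7 mL.min-1.g-1, the higher of the two numbers, and the gap between compound 2 and compound 1 lies beyond the usual scatter of repeated measurements. The two share the same bicyclic ether attached to the pyrimidine, but the rest of their structures differs in several places, so no single change can be read from the pair.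

The step considered here leads from compound 2 to compound 3, `CCNC(=O)Nc1ccc(-c2nccc([C@]34CCOC[C@H]3C4)n2)cc1`. The difference is the two compounds have the same atoms and bonds and differ only in configuration as drawn: 2 of 2 stereo elements differ (all stereocentres are inverted: mirror images); a stereocentre at a saturated ring carbon is drawn S in compound 2 and R in compound 3; a stereocentre at a saturated ring carbon is drawn R in compound 2 and S in compound 3. For the measured compounds named here, since compound 3 is the mirror image of compound 2, no measured pair in this set shows how such an inversion plays out in this assay. With nothing to point either way, the expected step from compound 2 to compound 3 is a 1.1-fold lower number from compound 2 to compound 3 (0.05 log units; within the scatter), that is, no change beyond the scatter. Compound 3 is therefore estimated at 15 mL.min-1.g-1, with a range from 6 mL.min-1.g-1 to 38 mL.min-1.g-1.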

Compound 3, intrinsic clearance in microsomes: 13.6 mL.min-1.g-1
The estimate for compound 3 lay 1.1-fold (0.04 log units) above the measured number; measured number inside the range.
By their numbers in this assay, from the lowest: compound 1; then compounds 3 and 2 (each within the scatter of the next).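

In this assay, inverting both stereocentres of the bicyclic ether gives a 1.2-fold lower number from compound 2 to compound 3 (0.09 log units; within the scatter) and so leaves the intrinsic clearance in microsomes unchanged beyond the scatter. For the compounds shown here, this is the first pair in the set that can be read as a single change, and nothing else separates its two members: the fact that compounds 2 and 3 differ only in the configuration as drawn. Compound 1 differs from compound 2 in several places at once and could say nothing about configuration, whereas this pair shows that, with the rest of the structure held fixed, the mirror-image forms of the bicyclic ether cannot be told apart in this read-out.

Whether the same holds in the more heavily substituted setting of compound 1, which gives 1.4 mL.min-1.g-1 in this assay, remains open, since only one mirror-image pair is shown and it rests on a single structure. Also open, going by these compounds, is how the number would respond if the bicyclic ether itself gave way to a different group at this position, such as an amine or a carboxylic acid, rather than only being inverted.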